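The source may hold more compounds than are shown below. What is called first, only, known or untested is meant among the compounds shown, and "the series" means these compounds.

Compound 1 `Cc1ccc([N+](=O)[O-])cc1S(=O)(=O)N(C)/N=C/c1cnn2ccc(Br)cc12` and compound 2 `Cc1ccc([N+](=O)[O-])cc1S(=O)(=O)N(C)/N=C/c1cnn2ccc(C3CC3)cc12` share a core and differ only at one aromatic carbon, where compound 1 carries bromo and compound 2 carries cyclopropyl. In an assay on isolated protein for inhibition of phosphatidylinositol 4,5-bisphosphate 3-kinase catalytic subunit beta isoform (Homo sapiens), read by 33P incorporation, with a stated time of 60 min (on this read-out lower numbers stand for stronger inhibition and higher numbers for weaker inhibition), compound 1 gives 230 nM. For compound 2 this assay reports no number but only a limit, > 1000 nM. The change from bromo to cyclopropyl therefore brings an at least 4.3-fold higher number from compound 1 to compound 2 (0.63 log units; beyond the scatter). Because (the limit of > 1000 nM in this assay, at which 1 of the 2 values shown sits), the exact position of compound 2 is not known, only that it sits at the weak end of the two values shown.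

Compound 3 `Cc1ccc([N+](=O)[O-])cc1S(=O)(=O)N(C)/N=C/c1cnn2ccc(C(N)=O)cc12` is not yet measured. It differs from compound 2 by carbamoyl in place of cyclopropyl on an aromatic carbon. Within the data shown here, the only measured step touches the same aromatic carbon but exchanges different groups, so it gives no direct guide to the direction of the present change, and a step in either direction, or none beyond the scatter, remains possible. For compound 3 the expected step is estimated as an at least 1.1-fold lower number from compound 2 to compound 3 (0.04 log units; that floor lies within the scatter). In this assay compound 3 is estimated at 900 nM, with a range from 150 nM to 6000 nM.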

Compound 3, half-maximal inhibitory concentration: > 1000 nM
Compound 3 was reported as a limit (the forecaster's own chance of this, stated with the estimate: 45%); middle value at least 1.1-fold (0.04 log units) from the limit.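

In this assay the change from bromo to carbamoyl brings an at least 4.3-fold higher number from compound 1 to compound 3 (0.63 log units; beyond the scatter) and so is a step towards weaker inhibition, the second such step seen at this aromatic carbon. Among the three compounds shown, bromo is therefore the only group with a measured number, and both replacements end at the assay's limit, even though cyclopropyl has no hydrogen-bond donor or acceptor and carbamoyl has one of each. Carbamoyl and cyclopropyl cannot be put in order, and the step between compound 2 and compound 3 cannot be read, because neither compound has an exact value: the limit of > 1000 nM in this assay, at which 2 of the 3 values shown sit.

On these data alone, how far beyond that limit compound 2 and compound 3 really lie remains open, so the two groups could be nearly equal or far apart. Also open, as far as these compounds go, is whether another group at this carbon, such as chloro, methyl, an amine or a carboxylic acid, would keep the inhibition seen with bromo, or even improve on it.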